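The source may report more compounds than this note shows. Statements on the series, on what has been measured and on what is new or still open speak of the compounds shown alone.

Measured so far in a functional assay on K562 cells (Homo sapiens) for cytotoxicity; on this read-out lower numbers stand for stronger inhibition and higher numbers for weaker inhibition:
- compound 1 `Cc1nc(O)c2cc(CSC(=S)N3CCCCC3)ccc2n1`: 11300 nM
- compound 2 `Cc1nc(O)c2cc(CSC(=S)N3CCOCC3)ccc2n1`: 7200 nM

Compound 2 stands at the lowest of these two numbers in this assay; its nearest neighbour is compound 1, and the step of a 1.6-fold lower number from compound 1 to compound 2 (0.20 log units; within the scatter) lies within the scatter. Compound 3 `Cc1nc(O)c2cc(CSC(=S)N3CC(C)OC(C)C3)ccc2n1` is not yet measured; it differs from compound 2 by 2,6-dimethylmorpholin-4-yl in place of morpholin-4-yl on a thiocarbonyl carbon. Going by the values given here, the single known step, a 1.6-fold lower number from compound 1 to compound 2 (0.20 log units; within the scatter), exchanges one ring for another and says nothing about methyls on that ring, so it bears on this change only loosely; no step beyond the scatter is known. For compound 3 a step of a 1.1-fold lower number from compound 2 to compound 3 (0.04 log units; within the scatter) is expected in this assay, that is none beyond the scatter. The estimate for compound 3 in this assay is 6500 nM, range 2500 nM to 16000 nM.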

Compound 3, half-maximal inhibitory concentration: 3700 nM
Compound 3: the middle estimate sits 1.8-fold (0.24 log units) above what was measured; the measured number falls inside the stated range.
By their numbers in this assay, from the lowest: compounds 3, 2 and 1 (each within the scatter of the next, the first and the last beyond it).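

In this assay, going by these compounds alone, 2,6-dimethylmorpholin-4-yl in place of morpholin-4-yl on a thiocarbonyl carbon gives a 1.9-fold lower number from compound 2 to compound 3 (0.29 log units; within the scatter), so the two methyls bring no step that can be told from the scatter. Against piperidin-1-yl, the same group gives a 3.1-fold lower number from compound 1 to compound 3 (0.48 log units; beyond the scatter), the only step in this series beyond the scatter, and a modest one. Nothing available bears on a reason for either step.

Open, on these data alone, is whether a piperazine with a free amine, or an open-chain diethylamino group, at this place would give a larger step. Also open, as far as these compounds go, is how a single methyl on the morpholine ring would compare.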